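The source may hold more compounds than are shown below. What is called first, only, known or untested is meant among the compounds shown, and "the series" means these compounds.

Measured compounds:
compound 1 `COc1ccc(C(=O)Oc2cc3c(cc2C)[C@@H](C(C)C)CC=C3C)cc1` — 46.5%
compound 2 `COc1ccc(C(=O)Oc2cc3c(C)ccc(C(C)C)c3cc2C)cc1` — 88.6%
compound 3 `Cc1cc2c(C(C)C)ccc(C)c2cc1OC(=O)c1ccc(C(F)(F)F)cc1` — 45.1%

The three compounds were tested in a functional assay on K562 cells (Homo sapiens) for antiproliferative activity, read by sulforhodamine B assay, with a stated time of 48 h, tested at 50 uM; on this read-out higher numbers stand for more inhibition at the one concentration tested (going by the name of the read-out) and lower numbers for less inhibition. Among them compound 1 stands second highest of three numbers; its nearest neighbour is compound 3, which lies within the scatter of it, and the furthest is compound 2, which lies well beyond the scatter above it. Compound 2 and compound 3 share a core and differ only in the group on the aromatic carbon of the ester ring, and that single step shows a number 43.5 percentage points lower from compound 2 to compound 3 (beyond the scatter).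

The untested compound 4 `CC1=CC[C@H](C(C)C)c2cc(C)c(OC(=O)c3ccc([N+](=O)[O-])cc3)cc21` is made from compound 1 by a change at the same ring position: nitro in place of methoxy on an aromatic carbon. Among the measured compounds shown here, no measured pair shows nitro entering in place of methoxy, so the step from compound 2 to compound 3, in which methoxy also leaves that aromatic carbon, is the only one that bears on the question, and it was large and downward. On that basis a downward step of moderate size in this assay is expected for compound 4, with considerable uncertainty because the entering group is different: a number 16.5 percentage points lower from compound 1 to compound 4 (beyond the scatter). Compound 4 is therefore estimated at 30%, in the range from 10% to 55%.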

Compound 4, a percentage reported as inhibition, at one concentration (the size of the read-out at that concentration, not a potency): 89%
Compound 4: middle estimate off by 59 percentage points, on the low side; measured number above the stated range.
By their numbers in this assay, from the lowest: compounds 3 and 1 (each within the scatter of the next); then compounds 2 and 4 (each within the scatter of the next).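

In this assay nitro in place of methoxy shows a number 42.5 percentage points higher from compound 1 to compound 4 (beyond the scatter) and so makes clear that losing methoxy from this aromatic carbon does not by itself go with a lower number. Among the compounds shown here, the only other step at this position, a number 43.5 percentage points lower from compound 2 to compound 3 (beyond the scatter), runs the opposite way, with trifluoromethyl entering on a different core, so the same leaving group now appears in large steps of opposite direction. Nothing in the data shown accounts for this difference in direction.

Still open, on these data alone, is whether nitro would give a comparable number on the core of compound 2, and whether trifluoromethyl would give a lower number on the core of compound 1, so the share of the entering group and the share of the core in these two steps cannot yet be told apart. The compounds shown also leave unanswered how an amine or a carboxylic acid on this aromatic carbon, para to a large group, would read in this assay on either core.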